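Replacing the side group of compound 3 with 2-methoxybutyl

The source may report more compounds than this note shows. Statements on the series, on what has been measured and on what is new or still open speak of the compounds shown alone.

In a functional assay on DU-145 cells (Homo sapiens) for cytotoxicity, read by MTT assay (a lower number here means a stronger inhibitor, a higher number a weaker inhibitor), compound 1 `CC(=O)OCCO[C@H](CC=C(C)C)C1=CC(=O)c2c(O)ccc(O)c2C1=O` gives 15500 nM, compound 2 `CC(C)=CC[C@@H](OC(=O)C1CCCO1)C1=CC(=O)c2c(O)ccc(O)c2C1=O` gives 10500 nM and compound 3 `CC(C)=CC[C@@H](OC(=O)C1CCCOC1)C1=CC(=O)c2c(O)ccc(O)c2C1=O` gives 29700 nM. Compound 3 thus stands apart from only one of the others: a 2.8-fold higher number from compound 2 to compound 3 (0.45 log units; beyond the scatter), whereas a 1.9-fold higher number from compound 1 to compound 3 (0.28 log units; within the scatter). Compound 4 `CCC(CO[C@H](CC=C(C)C)C1=CC(=O)c2c(O)ccc(O)c2C1=O)OC` has 2-methoxybutyl in place of (oxan-3-yl)carbonyl on an oxygen on a saturated carbon. The closest guide is compound 1, which has 2-acetoxyethyl on that oxygen, and its step to compound 3 ran the opposite way, so a similarly small step toward a lower number is expected, possibly none beyond the scatter. The expected change is a 1.9-fold lower number from compound 3 to compound 4 (0.27 log units; within the scatter). Compound 4 is estimated at 16000 nM, within an expected range of 7000 nM to 36000 nM.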

Compound 4, half-maximal inhibitory concentration: 45700 nM
The estimate for compound 4 lay 2.9-fold (0.46 log units) below the measured number; measured number outside the range, above it.
By their numbers in this assay, from the lowest: compounds 2, 1, 3 and 4 (each within the scatter of the next, the first and the last beyond it).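

In this assay 2-methoxybutyl on this oxygen cannot be told apart from the (oxan-3-yl)carbonyl group (a 1.5-fold higher number from compound 3 to compound 4 (0.19 log units; within the scatter)), yet it gives a clearly higher number than the groups of the other two compounds (a 4.4-fold higher number from compound 2 to compound 4 (0.64 log units; beyond the scatter); a 2.9-fold higher number from compound 1 to compound 4 (0.47 log units; beyond the scatter)). A ring in the side group therefore does not set the order here: compound 1 and compound 4 both lack one, yet their numbers lie beyond the scatter of each other. No available evidence accounts for this result. Going by these compounds, whether an amine, a carboxylic acid or a longer chain on this oxygen would bring the number below that of compound 2 remains open.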